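The source may report more compounds than this note shows. Statements on the series, on what has been measured and on what is new or still open speak of the compounds shown alone.

Compound 2 `Cn1nc(-c2ccc(C(N)=O)cc2)s/c1=N\C1CCC(O)CC1` has been examined in an in vivo ADME assay on the whole organism (Eutheria) for pharmacokinetics (a lower number here means that a smaller share of the oral dose reaches the circulation, a higher number that a larger share of the oral dose reaches the circulation), where compound 2 gives 7%. Within the data shown here, that is the only number recorded for compound 2 in this assay; one further entry for it carries no number. A related compound, compound 1 `Cn1nc(-c2ccc(C(N)=O)cc2)s/c1=N\C1CCCC(O)C1`, appears with two entries in this assay, and compound 1 gives 61.2%; 38.5% (2 entries). The spread between those two entries, (the several entries of compound 1 in this assay, 61.2%; 38.5% (2 entries)), shows how far repeats of this assay can lie apart for a single compound. Among the measured compounds shown here, both results of compound 1 stand above the single number of compound 2. Compound 3 `Cn1nc(-c2ccc(C(N)=O)cc2)s/c1=N\C1CCCCC1O` has the same atoms as compound 2, joined differently: 2-hydroxycyclohexyl in place of 4-hydroxycyclohexyl on a double-bonded nitrogen. For the measured compounds named here, no measured pair shows this change, so any expectation rests on compound 2 alone and on the spread seen for compound 1. The expected change, a number 18 percentage points higher from compound 2 to compound 3 (beyond the scatter), points upward in this assay, though its size is uncertain. Compound 3 is therefore estimated at 25%, within a range from 5% to 60%.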

Compound 3, oral bioavailability: 24.7%
Beside the measured number, compound 3's estimate is 0.3 percentage points above it; low and high end bracket the measured number.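

In this assay, among these compounds, 2-hydroxycyclohexyl in place of 4-hydroxycyclohexyl on a double-bonded nitrogen gives a number 17.7 percentage points higher from compound 2 to compound 3 (beyond the scatter), the first step that can be read at this position. The two groups hold the same atoms and the same counts of hydrogen-bond donors and acceptors, so how those atoms are joined is enough to shift this read-out. The step lies beyond the usual scatter, yet its exact size deserves caution, as repeats of a single compound can lie far apart: the several entries of compound 1 in this assay, 61.2%; 38.5% (2 entries)

The compounds shown give no reason for the step, and all of them carry a hydroxyl on the cyclohexyl ring. From the compounds shown here alone, whether an amine, a methoxy group or a plain cyclohexyl would give a similar share of the oral dose in the circulation remains open.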